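Trimming an Acetyl to Methyl: Expected Cytotoxicity

The source may report more compounds than this note shows. Statements on the series, on what has been measured and on what is new or still open speak of the compounds shown alone.

Of the two compounds measured in a functional assay on HeLa cells (Homo sapiens) for cytotoxicity, read by XTT assay, with a stated time of 72 h (on this read-out higher numbers stand for weaker inhibition and lower numbers for stronger inhibition), compound 2 `COc1cc(/C(=N/NC(C)=O)c2ccc3c(ccn3C)c2)cc(OC)c1OC` stands at the weaker end with 2300 nM. Among the measured compounds shown here, its only measured neighbour, compound 1 `COc1cc(C(OC(C)=O)c2ccc3c(ccn3C)c2)cc(OC)c1OC`, gives 6.4 nM in this assay, a gap far beyond the scatter. Compound 3 `CN/N=C(/c1cc(OC)c(OC)c(OC)c1)c1ccc2c(ccn2C)c1` is compound 2 with methyl in place of acetyl on an amine nitrogen, so the acetamido fragment becomes methylamino. For the measured compounds named here, no measured pair shows this exact change, so the direction remains uncertain. A modest improvement in this assay is expected, a 1.9-fold lower number from compound 2 to compound 3 (0.28 log units; within the scatter), with a broad range around it. Compound 3 is therefore estimated at 1200 nM, between 200 nM and 8000 nM.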

Compound 3, half-maximal inhibitory concentration: > 1000 nM
Compound 3: only a limit was reported; the forecaster's own chance of this, stated with the estimate: 10%; the middle value is on the limit's open side.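

No step from compound 2 to compound 3 can be read, because compound 3 carries only a limit, not a number: the limit of > 1000 nM in this assay, at which 1 of the 3 values shown sits.

Going by these compounds, whether methyl in place of acetyl on an amine nitrogen strengthens or weakens inhibition stays open.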